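Amide ring swap: from methoxypyrrolidine to difluoromethylpiperidine

The compounds below may be only part of what the source reports. "The series", "measured", "known", "first", "only" and "open" are said of these compounds alone.

Three compounds share one core and differ only in the ring attached to the carbonyl carbon. Compound 1 `CCN(CC)S(=O)(=O)c1ccc(S(=O)(=O)N2CCC[C@@H](C(=O)N3CCC(OC)CC3)C2)cc1` carries a 4-methoxypiperidin-1-yl group there and, in a functional assay on MIA PaCa-2 cells (Homo sapiens) for inhibition, read by MTT assay, with a stated time of 3 days (on this read-out higher numbers stand for weaker inhibition and lower numbers for stronger inhibition), compound 1 gives 50 nM. Compound 2 `CCN(CC)S(=O)(=O)c1ccc(S(=O)(=O)N2CCC[C@@H](C(=O)N3CCS(=O)(=O)CC3)C2)cc1` carries 1,1-dioxothiomorpholin-4-yl instead; in this assay compound 2 gives 220 nM, and the change is a 4.4-fold higher number from compound 1 to compound 2 (0.64 log units; beyond the scatter). Compound 3 `CCN(CC)S(=O)(=O)c1ccc(S(=O)(=O)N2CCC[C@@H](C(=O)N3CC[C@H](OC)C3)C2)cc1` carries 3-methoxypyrrolidin-1-yl; compound 3 gives 460 nM, the highest of the three numbers, with a 9.2-fold higher number from compound 1 to compound 3 (0.96 log units; beyond the scatter) and a 2.1-fold higher number from compound 2 to compound 3 (0.32 log units; beyond the scatter).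

Compound 4 `CCN(CC)S(=O)(=O)c1ccc(S(=O)(=O)N2CCC[C@@H](C(=O)N3CCC(C(F)F)CC3)C2)cc1` is not yet measured. It differs from compound 3 by 4-(difluoromethyl)piperidin-1-yl in place of 3-methoxypyrrolidin-1-yl on a carbonyl carbon. The measured steps that bear on this are the two that leave the five-membered ring behind: the step from compound 3 back toward a six-membered ring reverses a 9.2-fold higher number from compound 1 to compound 3 (0.96 log units; beyond the scatter), and the step among six-membered rings, a 4.4-fold higher number from compound 1 to compound 2 (0.64 log units; beyond the scatter), shows that the substituent on such a ring also matters. Going by the values given here, since the difluoromethyl group is new here, no measured step covers it directly.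

The expectation is therefore a lower number for compound 4 than for compound 3, estimated as a 4.2-fold lower number from compound 3 to compound 4 (0.62 log units; beyond the scatter), with the uncertainty spanning the gap between the six-membered examples. Compound 4 is estimated at 110 nM, with a range from 30 nM to 400 nM.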

Compound 4, half-maximal inhibitory concentration: 140 nM
Compound 4: the middle estimate sits 1.3-fold (0.10 log units) below what was measured; measured number inside the range.
By their numbers in this assay, from the lowest: compound 1; then compounds 4 and 2 (each within the scatter of the next); then compound 3.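

In this assay replacing 3-methoxypyrrolidin-1-yl with 4-(difluoromethyl)piperidin-1-yl on the carbonyl carbon gives a 3.3-fold lower number from compound 3 to compound 4 (0.52 log units; beyond the scatter) and places all three six-membered rings shown lower than the single five-membered ring, although ring size and substituent change together in this step. The new pair that keeps the piperidine ring and changes only its substituent gives a 2.8-fold higher number from compound 1 to compound 4 (0.45 log units; beyond the scatter) so the substituent alone moves the number, and the group with no hydrogen-bond acceptor gives the higher number of the two. Against the 1,1-dioxothiomorpholin-4-yl ring, the new group gives a 1.6-fold lower number from compound 2 to compound 4 (0.20 log units; within the scatter) so this assay does not separate these two rings.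

Still open, from the compounds shown here alone, is how much ring size counts by itself, and how a plain piperidine, or a piperidine bearing a hydroxyl group or an amine, would compare with these compounds. Nothing measured here explains any of these differences.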